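Working notes: from compound 2 to compound 3

This account rests on a few compounds, and the source may have more. Where it says the series, first, only, none or still open, it means among the compounds named here.

Compound 1 (`O=C1/C(=C\c2ccccc2)S/C(=N/c2ccccc2)N1Cc1ccncc1`) at 25200 nM
Compound 2 (`COc1ccc(/C=C2/S/C(=N/c3ccccc3)N(Cc3ccncc3)C2=O)cc1OC`) at 28900 nM

Both values come from a functional assay on HepG2 cells (Homo sapiens) for cytotoxicity, read by MTT assay, with a stated time of 48 h (a lower number here means a stronger inhibitor, a higher number a weaker inhibitor), and lie within the scatter of each other, so compound 2 is not separated from compound 1 on these numbers. Compound 3 (`O=C1/C(=C\c2cccc(O)c2)S/C(=N/c2ccccc2)N1Cc1ccncc1`) carries 3-hydroxyphenyl in place of 3,4-dimethoxyphenyl on a double-bonded chain carbon bound to a double-bonded ring carbon. Among the compounds with values here, one measured step bears on this place, the exchange of phenyl for 3,4-dimethoxyphenyl (a 1.1-fold higher number from compound 1 to compound 2 (0.06 log units; within the scatter)). Within the data shown here, no measured compound carries 3-hydroxyphenyl, so the evidence is indirect and rests on a single pair. Judging from that step (a 1.1-fold higher number from compound 1 to compound 2 (0.06 log units; within the scatter)), no change beyond the scatter is expected in this assay for the new group. The expected step is a 1.2-fold lower number from compound 2 to compound 3 (0.08 log units; within the scatter) and the range is kept wide. For compound 3 the estimated value is 24000 nM with an expected range from 11000 nM to 50000 nM in the same read-out.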

Compound 3, half-maximal inhibitory concentration: 17600 nM
Compound 3: middle estimate off by 1.4-fold (0.13 log units), on the high side; the measured number falls inside the stated range.
By their numbers in this assay, from the lowest: compounds 3, 1 and 2 (each within the scatter of the next).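

In this assay the place on a double-bonded chain carbon bound to a double-bonded ring carbon now holds three different aryl groups, and none of the exchanges separates the compounds: 3-hydroxyphenyl in place of 3,4-dimethoxyphenyl gives a small step (a 1.6-fold lower number from compound 2 to compound 3 (0.22 log units; within the scatter)), and hydroxy in place of hydrogen on an aromatic carbon gives another (a 1.4-fold lower number from compound 1 to compound 3 (0.16 log units; within the scatter)). The earlier pair covered only phenyl and 3,4-dimethoxyphenyl, whereas this result extends the same flat reading to a group with a hydrogen-bond donor, so that neither the gain of that donor nor the loss of the larger group moves the number beyond the scatter. No supporting measurement accompanies these numbers, and no reason for them can be stated.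

The compounds shown leave open whether any substituent at this place can separate itself from the others, for instance a carboxylic acid or an amine on the phenyl ring, or a saturated ring or longer chain in its stead. They also leave open how the number responds to changes elsewhere on the shared core, which stays constant across all three compounds.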